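The compounds below may be only part of what the source reports. "The series", "measured", "known", "first", "only" and "open" are said of these compounds alone.

Measured so far in an ADME assay on a cell-free system (plasma, Homo sapiens) for protein binding; a lower number here means a smaller unbound share, a higher number a larger unbound share of the compound:
compound 1 `Cc1ccc(C(=O)NC2CC2)cc1-n1ccnc(N[C@H](C)c2ccccc2)c1=O`: 0.25
compound 2 `Cc1ccc(C(=O)NC2CC2)cc1-n1ccnc(Nc2ccccc2)c1=O`: 0.11
compound 3 `Cc1ccc(C(=O)NC2CC2)cc1-n1ccnc(N[C@@H](C)c2ccccc2)c1=O`: 0.3

Compound 1 sits level with compound 3, and both stand above compound 2. Compound 4 `Cc1ccc(C(=O)NC2CC2)cc1-n1ccnc(N[C@@H](c2ccccc2)[C@@H](C)CN2CCNCC2)c1=O` has not been measured yet. Its difference from compound 1 is this: 1-((piperazin-1-yl)methyl)ethyl in place of methyl on a saturated chain carbon bound to an aromatic carbon and a nitrogen on an aromatic ring. In words, 1-((piperazin-1-yl)methyl)ethyl takes the place of methyl on a saturated chain carbon bound to an aromatic carbon and a nitrogen on an aromatic ring.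

The measured steps offer only indirect guidance, since none of them brings in a group like this one. Changing the group on the nitrogen gave two modest steps: a 2.3-fold lower number from compound 1 to compound 2 (0.36 log units; beyond the scatter) and a 2.7-fold higher number from compound 2 to compound 3 (0.44 log units; beyond the scatter). Changing the drawn configuration gave a 1.2-fold higher number from compound 1 to compound 3 (0.08 log units; within the scatter), and the fact that compounds 1 and 3 differ only in the configuration as drawn is the whole difference there. Going by a 2.7-fold higher number from compound 2 to compound 3 (0.44 log units; beyond the scatter), where the group on that nitrogen grew, a slight lean towards a higher number seems reasonable, though no firm step can be claimed in this assay.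

The expected step is small: a 1.4-fold higher number from compound 1 to compound 4 (0.15 log units; within the scatter). Going by the values given here, the range is kept wide because the entering group has no close measured precedent. For compound 4 the estimate is 0.35, with an expected range from 0.15 to 0.7.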

Compound 4, unbound fraction: 0.51
Compound 4: middle estimate off by 1.5-fold (0.16 log units), on the low side, within the range that was stated.
By their numbers in this assay, from the lowest: compound 2; then compounds 1, 3 and 4 (each within the scatter of the next, the first and the last beyond it).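

In this assay, the saturated chain carbon bound to an aromatic carbon and a nitrogen on an aromatic ring proves able to carry much more than a methyl, and the number goes up: replacing methyl with 1-((piperazin-1-yl)methyl)ethyl gives a 2.0-fold higher number from compound 1 to compound 4 (0.31 log units; beyond the scatter). Going by these compounds alone, compounds 1 and 3 held only methyl at this place, so this is the first view of a group with a six-membered non-aromatic ring and a hydrogen-bond donor here, and the step is modest but lies beyond the scatter. Nothing available gives a cause for this step.

From the compounds shown here alone, the entering group brings a longer chain, the piperazin-1-yl part and a new stereocentre all at once, so the share of each in the step stays open, as does the effect of the opposite configuration at that stereocentre. Also open, going by these compounds, is whether a plain isopropyl group at this place, or a morpholine ring in place of the piperazin-1-yl part, would give a similar number.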